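Swapping Fluoro for Cyano: Expected Clearance of Compound 4

The compounds below may be only part of what the source reports. "The series", "measured", "known", "first", "only" and "open" are said of these compounds alone.

Of the compounds shown here, three have been measured in an ADME assay on microsomes from liver (Rattus norvegicus) for metabolic stability; on this read-out lower numbers stand for slow clearance and higher numbers for fast clearance. Compound 1 `NC(=O)[C@@H]1CC[C@H](c2ccc(OCc3ccc(F)cc3)cc2)N1` gives 1.8 mL.min-1.g-1, the second highest of the three numbers. Compound 2 `NC(=O)[C@@H]1CC[C@H](c2ccc(OCc3ccccc3F)cn2)N1` sits lowest, with compound 2 giving 0.6 mL.min-1.g-1, while compound 3 `NC(=O)[C@@H]1CC[C@H](c2cccc(Oc3ccccc3)c2)N1` gives 4 mL.min-1.g-1, the highest. Both neighbours lie beyond the usual scatter from compound 1. Compound 4 `N#Cc1ccc(COc2ccc([C@H]3CC[C@@H](C(N)=O)N3)cc2)cc1` has not been measured; it differs from compound 1 by cyano in place of fluoro on an aromatic carbon. Among the measured compounds shown here, no pair of measured compounds shows this same change, so there is no measured step to lean on. A small downward step in this assay is expected, estimated as a 1.2-fold lower number from compound 1 to compound 4 (0.08 log units; within the scatter). For compound 4 the expected value is 1.5 mL.min-1.g-1, with a range from 0.6 mL.min-1.g-1 to 3.5 mL.min-1.g-1.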

Compound 4, intrinsic clearance in microsomes: 0.6 mL.min-1.g-1
Estimate against measurement, compound 4: 2.5-fold (0.40 log units) above; the range from low to high includes it.
By their numbers in this assay, from the lowest: compounds 2 and 4 (each within the scatter of the next); then compound 1; then compound 3.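

In this assay, among the compounds shown here, cyano in place of fluoro, on an aromatic carbon para to a large group, gives the only one-place step available here (a 3.0-fold lower number from compound 1 to compound 4 (0.48 log units; beyond the scatter)). It shows that this position is not indifferent to substitution: the step lies beyond the usual scatter and points to the lower number. Nothing available here accounts for the step. From the compounds shown here alone, whether chloro, methoxy or an amine at this carbon would shift the number the same way remains open, as does whether the same swap would carry over to compound 2.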